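The source may hold more compounds than are shown below. What is called first, only, known or untested is meant among the compounds shown, and "the series" means these compounds.

Measured in a functional assay on MCF7 cells (Homo sapiens) for inhibition, read by MTT assay, with a stated time of 48 h; a lower number here means a stronger inhibitor, a higher number a weaker inhibitor:
- compound 1 `Oc1cccc(C(c2c[nH]c3ccc(Br)cc23)c2c[nH]c3ccc(Br)cc23)c1`: 2800 nM
- compound 2 `Brc1ccc2[nH]cc(C(c3ccc4ccccc4c3)c3c[nH]c4ccc(Br)cc34)c2c1`: 7100 nM

Of these two measured compounds, compound 2, at 7100 nM, has the higher number and is therefore the weaker inhibitor. Compound 3 `Brc1ccc(C(c2c[nH]c3ccc(Br)cc23)c2c[nH]c3ccc(Br)cc23)cc1` has not yet been measured. It keeps the shared core but carries 4-bromophenyl in place of naphthalen-2-yl on a saturated chain carbon bound to two aromatic carbons.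

Going by the values given here, only one measured step bears on this change, and it falls at the same place: a 2.5-fold higher number from compound 1 to compound 2 (0.40 log units; beyond the scatter). There, naphthalen-2-yl replaced 3-hydroxyphenyl, and the size of that step was modest. Compound 3 returns to a single aromatic ring, as in compound 1, but 4-bromophenyl is not 3-hydroxyphenyl, so only a partial return toward compound 1 is anticipated, and it may not clear the scatter. The expected change in this assay is a 1.6-fold lower number from compound 2 to compound 3 (0.20 log units; within the scatter). For compound 3 the estimated value is 4500 nM, with an expected range of 1800 nM to 11000 nM.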

Compound 3, half-maximal inhibitory concentration: 3200 nM
Estimate against measurement, compound 3: 1.4-fold (0.15 log units) above; the measured number falls inside the stated range.
By their numbers in this assay, from the lowest: compounds 1 and 3 (each within the scatter of the next); then compound 2.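

At this position, on a saturated chain carbon bound to two aromatic carbons, 4-bromophenyl in place of naphthalen-2-yl gives a 2.2-fold lower number from compound 2 to compound 3 (0.35 log units; beyond the scatter) in this assay, so a second single-ring group now sets itself apart from the two-ring naphthalen-2-yl, and the gap seen earlier no longer rests on compound 1 alone. The two single-ring groups, however, are not separated: 4-bromophenyl in place of 3-hydroxyphenyl gives a 1.1-fold higher number from compound 1 to compound 3 (0.06 log units; within the scatter), which shows that, among these compounds, the hydroxyl of compound 1 is not needed to keep the number at that level. Nothing available explains why naphthalen-2-yl stands apart from the two single-ring groups.

Going by these compounds alone, with only three groups compared, the shift from naphthalen-2-yl to 4-bromophenyl changes the ring count and adds a bromine at once, so the contribution of each remains open, and a plain phenyl group would help to separate them. From the compounds shown here alone, it also remains open how this position responds to a ring bearing a carboxylic acid or an amine, and how the numbers move when the bromine atoms of the shared core are replaced.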